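The source may hold more compounds than are shown below. What is called first, only, known or untested is meant among the compounds shown, and "the series" means these compounds.

Measured so far in a functional assay on A549 cells (Homo sapiens) for cytotoxicity, read by MTT assay, with a stated time of 72 h; a higher number here means a weaker inhibitor, a lower number a stronger inhibitor:
- compound 1 (`Cn1ccc2c(Oc3ccc(NC(=O)c4cc5cccnc5n(-c5ccccc5)c4=O)cc3)ncnc21`) gives 66200 nM
- compound 2 (`Cn1ccc2c(Oc3ccc(NC(=O)c4cc5cccnc5n(-c5ccc(F)cc5)c4=O)cc3F)ncnc21`) gives 7320 nM
- compound 3 (`O=C(Nc1ccc(Oc2ncnc3[nH]ccc23)c(F)c1)c1cc2cccnc2n(-c2ccc(F)cc2)c1=O`) gives 5290 nM

Compound 3 (5290 nM) lies within the usual scatter of compound 2 (7320 nM), while compound 1 (66200 nM) has a higher number, beyond the scatter from compound 3.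

Compound 4 (`O=C(Nc1ccc(Oc2ncnc3[nH]ccc23)c(F)c1)c1cc2cccnc2n(-c2ccc(Br)cc2)c1=O`) has not yet been measured. It differs from compound 3 in one place (bromo in place of fluoro on an aromatic carbon): bromo in place of fluoro on an aromatic carbon, para to a large group, which turns 4-fluorophenyl into 4-bromophenyl.

Among the measured compounds shown here, no measured single-place step changes this group. For the measured compounds named here, the only such step (a 1.4-fold lower number from compound 2 to compound 3 (0.14 log units; within the scatter)) is hydrogen in place of methyl on an aromatic nitrogen, a different change, and it stays within the scatter. Compound 1 differs from compound 2 in more than one place, so the gap between their values cannot be tied to one change. The data therefore give no direct guide, and no shift beyond the scatter is expected in this assay, in either direction. The expected step is small (a 1.2-fold lower number from compound 3 to compound 4 (0.07 log units; within the scatter)). For compound 4 the estimated value is 4500 nM, with an expected range that is wide (1800 nM to 11000 nM).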

Compound 4, half-maximal inhibitory concentration: 27300 nM
Compound 4: middle estimate off by 6.1-fold (0.78 log units), on the low side; the whole stated range lies below it.
By their numbers in this assay, from the lowest: compounds 3 and 2 (each within the scatter of the next); then compound 4; then compound 1.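

Changing one halogen for another on this ring is not a neutral swap: in this assay the step reads a 5.2-fold higher number from compound 3 to compound 4 (0.71 log units; beyond the scatter), which is beyond the usual scatter. Among the compounds shown here, the only single-place step available earlier, a 1.4-fold lower number from compound 2 to compound 3 (0.14 log units; within the scatter), stayed within the scatter and concerned the aromatic nitrogen, so this is the first sign that a one-atom change can shift the number clearly, here towards a weaker inhibitor, with the 4-bromophenyl group giving the higher number than the 4-fluorophenyl group. The data offered here contain no measurement that accounts for this shift, so it stands as an observation on a single pair of compounds.

From the compounds shown here alone, with only fluoro and bromo compared directly at this place, it remains open where chloro, methoxy or an amine on the same aromatic carbon would fall. Going by these compounds, it is also open whether the same change from fluoro to bromo would produce a similar step with methyl on the aromatic nitrogen, as in compound 2, or whether the step holds only for the hydrogen form seen in compound 3.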